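The compounds below may be only part of what the source reports. "The series", "measured", "known", "first", "only" and "open" are said of these compounds alone.

Compound 3, `COC(=O)c1cnc(C(O)CCCCCCc2ccccc2)o1`, stands at the lowest of the two numbers measured in an assay (Rattus norvegicus) for inhibition of Fatty-acid amide hydrolase 1 (Homo sapiens); a higher number here means a weaker inhibitor, a lower number a stronger inhibitor: compound 3 gives 2000 nM. Among the measured compounds shown here, its nearest neighbour is compound 2, `N#Cc1cnc(C(O)CCCCCCc2ccccc2)o1`, which in this assay gives 4200 nM; the one step measured, a 2.1-fold lower number from compound 2 to compound 3 (0.32 log units; beyond the scatter), is the whole of the evidence on substituent changes at that ring position. The third value, for compound 1, `O=C(CCCCCCc1ccccc1)c1ncc(-c2ncccc2C(=O)O)o1`, is a limit of this assay rather than a number: compound 1 gives > 50 nM, and the limit of > 50 nM in this assay, at which 1 of the 3 values shown sits, is all that is known of it.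

Compound 4, `O=C(O)c1cccc(-c2cnc(C(O)CCCCCCc3ccccc3)o2)n1`, differs from compound 3 in one place: 6-carboxypyridin-2-yl in place of methoxycarbonyl on an aromatic carbon. For the measured compounds named here, no measured step bears directly on this exchange. Going by the values given here, the step that is known, from nitrile to methoxycarbonyl, was modest, and the only compound carrying the 6-carboxypyridin-2-yl group, compound 1, reports a limit and therefore sets no size. On this thin footing, the step in this assay from the ester to the larger group is expected to be small, in either direction, and possibly within the scatter. Compound 4 is therefore estimated at 1500 nM in this assay, within a range of 300 nM to 8000 nM, meaning an expected step of a 1.3-fold lower number from compound 3 to compound 4 (0.12 log units; within the scatter).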

Compound 4, inhibition constant: > 10000 nM
Compound 4: only a limit was reported (the forecaster's own chance of this, stated with the estimate: 15%); middle value at least 6.6-fold (0.82 log units) away from the limit.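

In this assay, 6-carboxypyridin-2-yl in place of methoxycarbonyl, on the aromatic carbon next to the ring oxygen, gives an at least 5.0-fold higher number from compound 3 to compound 4 (0.69 log units; beyond the scatter), and the same group in place of cyano gives an at least 2.3-fold higher number from compound 2 to compound 4 (0.37 log units; beyond the scatter). This position had until now shown only a 2.1-fold lower number from compound 2 to compound 3 (0.32 log units; beyond the scatter), and it now proves not to treat all groups alike, since the larger entering group goes with a weaker inhibitor than either the nitrile or the methyl ester. Compound 4 is recorded only as a limit, so both new steps set a lower bound on the size of the change and no more: the limit of > 10000 nM in this assay, at which 1 of the 4 values shown sits.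

The compounds shown do not separate the pyridine ring from the carboxylic acid, and a plain pyridin-2-yl or phenyl group at this position would speak to that question. What a ketone in place of the alcohol does also stays open, for compound 1 reports only a limit and differs from compound 4 in more than one place: the limit of > 50 nM in this assay, at which 1 of the 4 values shown sits.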